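A Fluorine Joins the Benzyl Arm of Compound 3

The source may hold more compounds than are shown below. What is called first, only, known or untested is meant among the compounds shown, and "the series" means these compounds.

Compound 3 `COc1ccc(C2N=C(SCc3ccccc3)NC(C)=C2C(=O)Nc2ccc(Br)cc2)cc1` gives 11.3% in a functional assay on the whole organism (artery, strain albino) with Rattus norvegicus as the target, with a stated time of 600 min, at a dose of 10 mg/kg by the oral route (a higher number here means more inhibition at the dose given (going by the name of the read-out), a lower number less inhibition), the lowest of the three numbers measured. Compound 1 `CC1=C(C(=O)Nc2ccc(Br)cc2)C(c2ccc(Cl)cc2Cl)N=C(SCc2ccccc2)N1` gives 17.4%, and the two lie close: a number 6.1 percentage points lower from compound 1 to compound 3 (within the scatter), a change of 4-methoxyphenyl in place of 2,4-dichlorophenyl on a saturated ring carbon. Compound 2 `CC1=C(C(=O)Nc2ccc(Br)cc2)C(c2ccc(Cl)cc2Cl)N=C(SCc2ccc(Cl)cc2)N1` gives 30.3%, and the step of a number 12.9 percentage points higher from compound 1 to compound 2 (beyond the scatter) came from chloro in place of hydrogen on an aromatic carbon of the benzylsulfanyl group.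

Compound 4 `COc1ccc(C2N=C(SCc3ccc(F)cc3)NC(C)=C2C(=O)Nc2ccc(Br)cc2)cc1` has not yet been measured. The change from compound 3 is fluoro in place of hydrogen on an aromatic carbon. The step from compound 1 to compound 2 is the one that bears on it, since a halogen enters the same benzyl ring there, and that step was modest yet beyond the scatter. With a fluoro entering rather than a chloro, a smaller rise is expected, one that may not clear the scatter: a number 6.7 percentage points higher from compound 3 to compound 4 (within the scatter) is the estimated step. Compound 4 is therefore expected to give about 18%, within a range from 8% to 30%.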

Compound 4, a percentage reported as inhibition, in the whole organism at one dose (the size of the read-out at that dose, not a potency): 24.1%
Compound 4: middle estimate off by 6.1 percentage points, on the low side; the measured number falls inside the stated range.
By their numbers in this assay, from the lowest: compounds 3, 1, 4 and 2 (each within the scatter of the next, the first and the last beyond it).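

Within the data shown here, the fluoro group of the (4-fluorobenzyl)sulfanyl arm gives a rise that clears the scatter, a number that the earlier compounds could not have supplied for this halogen (a number 12.8 percentage points higher from compound 3 to compound 4 (beyond the scatter)). Among these compounds, until now, the only halogen step on the benzyl ring was chloro with a 2,4-dichlorophenyl group on the saturated ring carbon (a number 12.9 percentage points higher from compound 1 to compound 2 (beyond the scatter)). The rise now also appears with a 4-methoxyphenyl group there, so in these two pairs a halogen on the benzyl ring goes with a higher number, though nothing available accounts for it.

As far as these compounds go, whether chloro would do the same on compound 3, or fluoro on compound 1, stays open. So does what an amine or a carboxylic acid would do in place of the same hydrogen.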